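The source may hold more compounds than are shown below. What is called first, only, known or untested is meant among the compounds shown, and "the series" means these compounds.

Compound 1 `O=C(/C=C\Nc1ccc(F)cc1)c1cn(-c2ccccc2)nc1-c1ccc(F)cc1` was tested in an ADME assay on HaCaT cells (Homo sapiens) for antiproliferative activity, read by MTT assay, with a stated time of 48 h; a lower number here means a stronger inhibitor, a higher number a weaker inhibitor. Going by these compounds, for compound 1 only a limit is recorded, > 50000 nM, so its exact standing among the numbers remains open (the limit of > 50000 nM in this assay, at which 1 of the 3 values shown sits). Two close relatives do have numbers: compound 2 `O=C(/C=C\Nc1ccc(Cl)cc1)c1cn(-c2ccccc2)nc1-c1ccc(F)cc1` gives 21300 nM, and compound 3 `COc1ccc(N/C=C\C(=O)c2cn(-c3ccccc3)nc2-c2ccc(F)cc2)cc1` gives 19600 nM. Compound 4 `COc1ccc(-c2nn(-c3ccccc3)cc2C(=O)/C=C\Nc2ccc(F)cc2)cc1` differs from compound 1 by methoxy in place of fluoro on an aromatic carbon. The same swap of fluoro for methoxy has been seen once, at a different place in the molecule, where an at least 2.5-fold lower number from compound 1 to compound 3 (0.40 log units; beyond the scatter); the chloro swap at that place gave an at least 2.3-fold lower number from compound 1 to compound 2 (0.37 log units; beyond the scatter). Both point toward a lower number, so for compound 4 a modest step in that direction is expected, an at least 1.6-fold lower number from compound 1 to compound 4 (0.22 log units; that floor lies within the scatter). Compound 4 is estimated at 30000 nM, expected to lie between 10000 nM and 100000 nM.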

Compound 4, half-maximal inhibitory concentration: 8910 nM
Compound 4: the middle estimate sits 3.4-fold (0.53 log units) above what was measured, and the stated range ends above it.
By their numbers in this assay, from the lowest: compound 4; then compounds 3 and 2 (each within the scatter of the next). At a limit, above all of these: compound 1.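

In this assay the change from 4-fluorophenyl to 4-methoxyphenyl gives an at least 5.6-fold lower number from compound 1 to compound 4 (0.74 log units; beyond the scatter) at this position, so the ring that the earlier swaps left untouched also responds to a change of group. That step is only a floor because compound 1 carries a limit and not a number: the limit of > 50000 nM in this assay, at which 1 of the 4 values shown sits.

The compounds shown leave open whether another group at this position, such as a hydroxyl, an amine or an ethoxy, would lower the number further. They also cannot tell why methoxy lowers it here.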